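Dioxolanylmethyl for the hydroxylated oxolanyl: compound 1 to compound 4

The compounds below may be only part of what the source reports. "The series", "measured", "known", "first", "only" and "open" are said of these compounds alone.

Measured in a functional assay on MCF7 cells (Homo sapiens) for cytotoxicity, read by MTT assay, with a stated time of 72 h; a higher number here means a weaker inhibitor, a lower number a stronger inhibitor:
- compound 1 `O=C1c2c[n+]([O-])c3ccccc3c2C(=O)c2c1c1ccccc1n2Cc1cn([C@H]2O[C@H](CO)[C@@H](O)[C@H]2O)nn1` gives 1490 nM
- compound 2 `CC1(C)OCC(Cn2cc(Cn3c4c(c5ccccc53)C(=O)c3c[n+]([O-])c5ccccc5c3C4=O)nn2)O1` gives 290 nM
- compound 3 `CN1CCN(CCCCn2c3c(c4ccccc42)C(=O)c2c[n+]([O-])c4ccccc4c2C3=O)CC1` gives 100 nM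

Compound 4 `CC1(C)OC[C@@H](Cn2cc(Cn3c4c(c5ccccc53)C(=O)c3c[n+]([O-])c5ccccc5c3C4=O)nn2)O1` has not yet been measured. Of the three measured compounds, compound 1 has the highest number and therefore stands at the weak end of this small set. The move to compound 4 is this change: (2,2-dimethyl-1,3-dioxolan-4-yl)methyl in place of 3,4-dihydroxy-5-(hydroxymethyl)oxolan-2-yl on an aromatic nitrogen. Among the measured compounds shown here, the same exchange of groups has been measured once, and it is the only measured step that bears directly on this change: a 5.1-fold lower number from compound 1 to compound 2 (0.71 log units; beyond the scatter). That step is modest but clear of the scatter. For the measured compounds named here, compound 3 offers no comparable step and only marks the low end of the numbers. No measurement tests the defined stereocentre of compound 4 on its own, so this adds uncertainty to the comparison. Going by the values given here, on the single measured exchange, a step of similar size and the same direction, towards a lower number and beyond the scatter, is expected in this assay. The expected step is a 5.1-fold lower number from compound 1 to compound 4 (0.71 log units; beyond the scatter). The estimate for compound 4 is 290 nM, with an expected range of 130 nM to 640 nM.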

Compound 4, half-maximal inhibitory concentration: > 1000 nM
Compound 4: no number, only a limit (the forecaster's own chance of this, stated with the estimate: 3%); middle value at least 3.4-fold (0.53 log units) from the limit.
By their numbers in this assay, from the lowest: compound 3; then compound 2; then compound 1.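

In this assay compound 4 gives > 1000 nM, and this value is a limit, not a number. The exchange of 3,4-dihydroxy-5-(hydroxymethyl)oxolan-2-yl for (2,2-dimethyl-1,3-dioxolan-4-yl)methyl therefore cannot be read for compound 4, so the earlier single exchange gains no second reading, while the gap between the two dioxolanylmethyl compounds can be read as an at least 3.4-fold higher number from compound 2 to compound 4 (0.53 log units; beyond the scatter). With the same atoms and bonds in both compounds, the only drawn difference that goes with this gap is the stereocentre at a saturated ring carbon, without a configuration in compound 2 and R in compound 4: the fact that one of compounds 2 and 4 is drawn with a defined configuration and the other without, at the place where they differ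

Left open are how far compound 4 lies past its limit and how the S configuration at this carbon would read in this assay. Also open, from the compounds shown here alone, is how a 2,3-dihydroxypropyl group, carrying the two hydroxyl groups in an open chain, would read on the aromatic nitrogen of the five-membered aromatic ring with 3 nitrogen.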